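Swapping a Five-Membered Ring for Pyrimidine on the Core

The source may hold more compounds than are shown below. What is called first, only, known or untested is meant among the compounds shown, and "the series" means these compounds.

Three measured compounds share one core and differ only in the ring attached to it. Compound 1 `Cc1cc(-c2ccccc2NCC2=NCCN2)on1` gives 38.9 nM in a functional assay for activation of Alpha-1A adrenergic receptor (Homo sapiens), read by calcium flux (a lower number here means that less compound is needed, a higher number that more compound is needed for the effect), and compound 2 `c1ccc(-c2cnoc2)c(NCC2=NCCN2)c1` gives 45.7 nM. Compound 3 `Cc1nc(-c2ccccc2NCC2=NCCN2)no1` gives 724 nM, the highest of the three numbers; the steps of a 19-fold higher number from compound 1 to compound 3 (1.27 log units; beyond the scatter) and a 16-fold higher number from compound 2 to compound 3 (1.20 log units; beyond the scatter) are both large. Compound 4 `c1cnc(-c2ccccc2NCC2=NCCN2)nc1` carries the change (pyrimidin-2-yl in place of 5-methyl-1,2,4-oxadiazol-3-yl on an aromatic carbon). For the measured compounds named here, no measured step introduces a six-membered ring, so there is no direct guide; the two large steps only show that the identity of this ring moves the number strongly, and the new ring could go either way. Compound 4 is therefore expected to show a moderate step of a 2.4-fold lower number from compound 3 to compound 4 (0.38 log units; beyond the scatter). The estimate for compound 4 is 300 nM, with a range from 60 nM to 1500 nM.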

Compound 4, half-maximal effective concentration: 10 nM
Beside the measured number, compound 4's estimate is 30-fold (1.48 log units) above it; measured number below the stated range.
By their numbers in this assay, from the lowest: compound 4; then compounds 1 and 2 (each within the scatter of the next); then compound 3.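

A six-membered ring is accepted at this position and gives the lowest number of the four compounds in this assay with one large step (a 72-fold lower number from compound 3 to compound 4 (1.86 log units; beyond the scatter)) and two modest ones (a 4.6-fold lower number from compound 2 to compound 4 (0.66 log units; beyond the scatter)) (a 3.9-fold lower number from compound 1 to compound 4 (0.59 log units; beyond the scatter)), all beyond the scatter. Ring size and the count of ring hetero atoms change together here, so these compounds cannot separate the two. No available evidence explains the drop in the number.

On these data alone, whether a plain phenyl ring in place of the pyrimidin-2-yl group, or an amine or methoxy group on it, would keep this low number remains open.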